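A Methoxyphenyl Group Replaces a Pyrimidinyl Group

The compounds below may be only part of what the source reports. "The series", "measured", "known", "first", "only" and "open" are said of these compounds alone.

Of the compounds shown here, three sharing one core have been measured in a functional assay, read by spectrophotometry, with a stated time of 30 min, tested at 5 ug/mL; on this read-out higher numbers stand for a stronger effect at the one concentration tested and lower numbers for a weaker effect. Compound 1 `CN1CCN(CC(=O)Nc2nc3ccccc3[nH]2)CC1` gives 11%. Compound 2 `CCN1CCN(CC(=O)Nc2nc3ccccc3[nH]2)CC1` gives 13.3%. Compound 3 `O=C(CN1CCN(c2ncccn2)CC1)Nc1nc2ccccc2[nH]1` gives 8.77%. The three numbers sit close together: a number 2.3 percentage points higher from compound 1 to compound 2 (within the scatter), a number 2.2 percentage points lower from compound 1 to compound 3 (within the scatter), and a number 4.5 percentage points lower from compound 2 to compound 3 (within the scatter). Compound 3 thus stands within the scatter of both compound 1 and compound 2, and nothing among the three sets it apart.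

Compound 4 `COc1ccc(N2CCN(CC(=O)Nc3nc4ccccc4[nH]3)CC2)cc1` differs from compound 3 in one place: 4-methoxyphenyl in place of pyrimidin-2-yl on an amine nitrogen in a ring. For the measured compounds named here, the steps that bear on this are the two replacements at the same ring nitrogen, from compound 1 and from compound 2 to compound 3, in which a pyrimidin-2-yl group took the place of a methyl or an ethyl group; both moved the reading by amounts inside the scatter. Going by the values given here, no measured step shows what an aromatic ring of carbon only, bearing a methoxy group, does at this position.

On that basis, no step beyond the scatter is expected from compound 3 to compound 4, and the estimated change is a number 1.2 percentage points higher from compound 3 to compound 4 (within the scatter). Compound 4 is expected to give about 10% in this assay, with a range from 2% to 22%.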

Compound 4, a percentage reported as activity, at one concentration (the size of the read-out at that concentration, not a potency) in the functional assay: 7.24%
Compound 4: middle estimate off by 2.8 percentage points, on the high side, within the range that was stated.
By their numbers in the functional assay, from the lowest: compounds 4, 3, 1 and 2 (each within the scatter of the next).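

In the functional assay the 4-methoxyphenyl group on this ring nitrogen gives a number 1.5 percentage points lower from compound 3 to compound 4 (within the scatter) and a number 6.1 percentage points lower from compound 2 to compound 4 (within the scatter) and a number 3.8 percentage points lower from compound 1 to compound 4 (within the scatter) with no step among the listed replacements leaving the scatter. An aromatic ring of carbon only, bearing a methoxy group, therefore joins methyl, ethyl and pyrimidin-2-yl at this position, and the four groups cannot be told apart by this reading, although they differ widely in size and in the atoms of the ring or chain. Yet the replacement that leaves this reading inside the scatter does separate the pair in a physicochemical assay for lipophilicity, read by spectrophotometry, using the shake flask method, measured as octanol-water partition, with a stated time of 24 h (a lower number here means a more polar compound, a higher number a more lipophilic compound), with compound 4 the more lipophilic: the measured partition coefficient of compound 3, 1.85, and of compound 4, 2.65, a number 0.80 log units higher (beyond the scatter). In the physicochemical assay compound 3 gives 1.85 and compound 4 gives 2.65.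

The compounds shown leave open whether a group of another kind on this ring nitrogen, such as a carboxylic acid, a benzyl group or a longer chain, would move the reading in the functional assay beyond the scatter. They also leave open whether a plain phenyl or a 4-chlorophenyl group would behave as the 4-methoxyphenyl group does here.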